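This account rests on a few compounds, and the source may have more. Where it says the series, first, only, none or still open, it means among the compounds named here.

Within the data shown here, compound 1 `O=C(/C=C/c1coc2ccccc2c1=O)Nc1nnn[nH]1` is the only member of this small set with a number to its name: in a functional assay on cells (Mast cell, Rattus norvegicus) for inhibition, with a stated time of 15 min (a higher number here means that more compound is needed for the effect, a lower number that less compound is needed), compound 1 gives 6 ug/mL. Compound 2 `O=C(Cl)/C=C/c1coc2ccccc2c1=O` stands nowhere on that scale, since in this assay compound 2 has no single number and the entry reads "nd(insoluble)" (no result reported). Compound 3 `O=c1c(/C=N/O)coc2ccccc12` arises from compound 2 through one change (a group of 3 heavy atoms (1 carbon, 1 nitrogen, 1 oxygen; no ring) in place of a group of 5 heavy atoms (3 carbon, 1 oxygen, 1 chlorine; no ring), on an aromatic carbon). Among the measured compounds shown here, with no measured step to lean on, a result in this assay somewhat weaker than compound 1 is expected, within broad bounds. For compound 3 the estimated value in this assay is 20 ug/mL, ranging from 5 ug/mL to 80 ug/mL.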

Compound 3, concentration for half-maximal effect: > 18 ug/mL
Compound 3 was reported as a limit; the forecaster's own chance of this, stated with the estimate: 25%; the middle value is on the limit's open side.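

Compound 2 has no single number in this assay, and compound 3 has only a limit, > 18 ug/mL, so no step can be read between them. As far as these compounds go, what the change between them does to the effect, and the exact value of compound 3, stay open.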